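Series notes: aryl swap from compound 2 to compound 4

A few compounds are considered here, and "the series" means these few. Any claim that something is new, unique, unknown or untested is made for them only; others in the source may bear on it.

Measured so far:
- compound 1 `CC1CCCC(C)N1CCCCCN1C(=O)C(c2ccccc2)Oc2ccccc21` gives 2.8% in an assay on isolated protein for inhibition of serine protease 1 (Homo sapiens), tested at 100 uM; on this read-out higher numbers stand for more inhibition at the one concentration tested (going by the name of the read-out) and lower numbers for less inhibition
- compound 2 `CC1CCCC(C)N1CCCCCN1C(=O)C(c2ccc(Cl)c(Cl)c2)Oc2ccccc21` gives 14%
- compound 3 `CC1CCCC(C)N1CCCCCN1C(=O)C(c2cccc(C(=N)NN3CCOCC3)c2)Oc2ccccc21` gives 58%

Compound 2 stands second highest of the three numbers. Compound 1 lies just under it, by the step of a number 11.2 percentage points higher from compound 1 to compound 2 (beyond the scatter); compound 3 stands furthest above it.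

Compound 4 `COc1ccc(C2Oc3ccccc3N(CCCCCN3C(C)CCCC3C)C2=O)cc1OC` differs from compound 2 in one place: 3,4-dimethoxyphenyl in place of 3,4-dichlorophenyl on a saturated ring carbon. Among the compounds with values here, the only measured step at this saturated ring carbon is a number 11.2 percentage points higher from compound 1 to compound 2 (beyond the scatter), a modest one. The large step of a number 55.2 percentage points higher from compound 1 to compound 3 (beyond the scatter) concerns a different group on an aromatic carbon and offers no guide here. Within the data shown here, no measured compound varies the 3,4-dichlorophenyl itself, so the direction is open; the step is expected to be small, a number 4 percentage points lower from compound 2 to compound 4 (within the scatter). Compound 4 is thus estimated at 10%, within 0% to 30%.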

Compound 4, a percentage reported as inhibition, at one concentration (the size of the read-out at that concentration, not a potency): 0%
Estimate against measurement, compound 4: 10 percentage points above, within the range that was stated.
By their numbers in this assay, from the lowest: compounds 4 and 1 (each within the scatter of the next); then compound 2; then compound 3.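

Replacing 3,4-dichlorophenyl with 3,4-dimethoxyphenyl on the saturated ring carbon gives a number 14 percentage points lower from compound 2 to compound 4 (beyond the scatter), so the gain seen with 3,4-dichlorophenyl is not shared by every 3,4-disubstituted phenyl at this position. Against plain phenyl, 3,4-dimethoxyphenyl gives a number 2.8 percentage points lower from compound 1 to compound 4 (within the scatter), so the two methoxy groups bring no measurable change. Nothing available here accounts for the difference between the chlorine and methoxy substituents. As far as these compounds go, it remains open whether a single chlorine, a single methoxy, a trifluoromethyl or a carboxylic acid on this phenyl would raise the number.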